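Trading tert-Butyl for Bromo on the Shared Core

The source may hold more compounds than are shown below. What is called first, only, known or untested is meant among the compounds shown, and "the series" means these compounds.

In a functional assay on HUVEC cells (Homo sapiens) for inhibition, with a stated time of 4 days (on this read-out lower numbers stand for stronger inhibition and higher numbers for weaker inhibition), compound 1 `COc1ccc(C(N)=O)cc1/C=C/c1ccc(Cl)cc1` gives 87 nM and compound 2 `COc1ccc(C(N)=O)cc1/C=C/c1ccc(C(C)(C)C)cc1` gives 370 nM. For the measured compounds named here, compound 2 therefore holds the higher, weaker number of the two measured so far. The next compound is compound 3 `COc1ccc(C(N)=O)cc1/C=C/c1ccc(Br)cc1`, and the change leading to it is bromo in place of tert-butyl on an aromatic carbon. In words, this is bromo in place of tert-butyl on an aromatic carbon of a six-membered aromatic ring of carbon only, para to a large group.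

Going by the values given here, only one measured step bears on this change: a 4.3-fold higher number from compound 1 to compound 2 (0.63 log units; beyond the scatter). There, tert-butyl took the place of chloro, and the step was modest but beyond the scatter. Compound 3 runs the same kind of swap the other way, although it ends on bromo rather than chloro. Among the compounds with values here, no measured compound carries bromo, so this comparison is only a guide. In this assay, a step of similar size towards a lower number is expected: a 3.7-fold lower number from compound 2 to compound 3 (0.57 log units; beyond the scatter). For compound 3 the estimated value is 100 nM, with an expected range from 40 nM to 250 nM.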

Compound 3, half-maximal inhibitory concentration: 560 nM
The estimate for compound 3 lay 5.6-fold (0.75 log units) below the measured number; the whole stated range lies below it.
By their numbers in this assay, from the lowest: compound 1; then compounds 2 and 3 (each within the scatter of the next).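

In this assay, the move to bromo gives a 1.5-fold higher number from compound 2 to compound 3 (0.18 log units; within the scatter) and so, on this aromatic carbon para to a large group, bromo and tert-butyl cannot be told apart, even though tert-butyl has 4 heavy atoms and bromo has 1 heavy atom. The exchange of chloro for bromo gives a 6.4-fold higher number from compound 1 to compound 3 (0.81 log units; beyond the scatter) and this shows that the two are not interchangeable at this position, leaving compound 1 the most potent of the three. No measurement available here explains why chloro and bromo part in this way.

The compounds shown leave open whether fluoro, methyl or an amine at this same position would give a number close to that of chloro or one in the range of bromo and tert-butyl. With only chloro, bromo and tert-butyl on a single shared core, no general rule for this position can yet be drawn.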